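Working notes: substituted variants of compound 1 in cytotoxicity

The source may report more compounds than this note shows. Statements on the series, on what has been measured and on what is new or still open speak of the compounds shown alone.

Measured compounds:
- compound 1 `CCOC(=O)C12C(=O)OCC=C1COC2c1ccccc1`, which in a functional assay on HeLa cells (Homo sapiens) for cytotoxicity, read by MTT assay (on this read-out lower numbers stand for stronger inhibition and higher numbers for weaker inhibition), gives 12800 nM
- compound 2 `CCOC(=O)C12C(=O)OCC=C1COC2c1ccc(F)cc1`, which in this assay gives 22900 nM
- compound 3 `CCOC(=O)C12C(=O)OCC=C1COC2c1ccc(Br)cc1`, which in this assay gives 48700 nM

Compound 1 holds the lowest number of the three in this assay. Its nearest neighbour is compound 2, separated by a step that sits within the scatter; its furthest is compound 3, separated by a step that lies beyond it.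

Compound 4 `CCOC(=O)C12C(=O)OCC=C1COC2c1ccc([N+](=O)[O-])cc1` differs from compound 1 in one place: nitro in place of hydrogen on an aromatic carbon. The two measured steps that bear on this change are a 1.8-fold higher number from compound 1 to compound 2 (0.25 log units; within the scatter) and a 3.8-fold higher number from compound 1 to compound 3 (0.58 log units; beyond the scatter). Both replacements of the same hydrogen moved the number upward, the second one modestly beyond the scatter, and the pair of substituted compounds are themselves separated by a 2.1-fold higher number from compound 2 to compound 3 (0.33 log units; beyond the scatter). Within the data shown here, no measured step involves a nitro group, so the expectation rests only on the direction shared by these two steps.

A modest upward step is therefore expected, of about a 2.3-fold higher number from compound 1 to compound 4 (0.37 log units; beyond the scatter). Compound 4 is estimated in this assay at 30000 nM, with a range from 12000 nM to 80000 nM.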

Compound 4, half-maximal inhibitory concentration: 53400 nM
The estimate for compound 4 lay 1.8-fold (0.25 log units) below the measured number, and the stated range covers the measured number.
By their numbers in this assay, from the lowest: compounds 1 and 2 (each within the scatter of the next); then compounds 3 and 4 (each within the scatter of the next).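

In this assay the position on the aromatic ring para to a large group now has a third replacement of hydrogen, and nitro gives a step beyond the scatter (a 4.2-fold higher number from compound 1 to compound 4 (0.62 log units; beyond the scatter)), as bromo does, while the fluoro step to compound 2 stays within it. Nitro and bromo cannot be told apart at this position (a 1.1-fold higher number from compound 3 to compound 4 (0.04 log units; within the scatter)), so compound 3 and compound 4 sit at one level even though the two groups differ in their atoms, with nitro bringing nitrogen and oxygen and bromo a halogen. Nitro does stand clear of fluoro (a 2.3-fold higher number from compound 2 to compound 4 (0.37 log units; beyond the scatter)), so the position separates some replacements from others, and the split in this set runs between compound 1 and compound 2 on one side and compound 3 and compound 4 on the other.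

The compounds shown offer no evidence on why these steps arise. Going by these compounds, whether an amine, a hydroxyl group or a carboxylic acid on the same aromatic carbon would keep to this level or move the number in the other direction remains open.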